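This account rests on a few compounds, and the source may have more. Where it says the series, first, only, none or still open, it means among the compounds named here.

The study concerns three measured compounds and one still to be tested. Compound 1 `Cc1cc(C)c2c(O)cc(-c3cccc4ccccc34)nc2n1` was run in a functional assay on U-251 cells (Homo sapiens) for antiproliferative activity (a higher number here means a weaker inhibitor of growth, a lower number a stronger inhibitor of growth), and gave 372 nM. Among the three numbers this stands second highest. Compound 2 `Cc1cnc2nc(-c3ccc4ccccc4c3)cc(O)c2c1` gives 468 nM in this assay, a value within the scatter of that of compound 1, so the two cannot be told apart. Compound 3 `Cc1cnc2[nH]c(-c3cccc(F)c3)cc(=O)c2c1` gives 40.7 nM in this assay, a number clearly below that of compound 1 and beyond the scatter. Compound 4 `Cc1ccnc2nc(-c3cccc4ccccc34)cc(O)c12` has not yet been measured in this assay. It differs from compound 1 in one place: hydrogen in place of methyl on an aromatic carbon. Among the compounds with values here, no pair of measured compounds differing in a single place is available here, so there is no measured step to lean on. Losing one methyl group is a modest change, and the expected step is a 1.2-fold higher number from compound 1 to compound 4 (0.08 log units; within the scatter), lying essentially within the scatter. For compound 4 the estimate is 450 nM, with a range from 170 nM to 1200 nM.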

Compound 4, concentration for 50% growth inhibition: < 10 nM
Compound 4: only a limit was reported; the forecaster's own chance of this, stated with the estimate: 2%; middle value at least 45-fold (1.65 log units) away from the limit.
By their numbers in this assay, from the lowest: compound 3; then compounds 1 and 2 (each within the scatter of the next). At a limit, below all of these: compound 4.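

Hydrogen in place of methyl on this aromatic carbon, next to the ring nitrogen, gives an at least 37-fold lower number from compound 1 to compound 4 (1.57 log units; beyond the scatter) in this assay, the first measured step in this set and a large one. It shows that this position is far from indifferent: removing a single methyl group, one heavy atom with no hydrogen-bond donors or acceptors, is enough to change the growth inhibition markedly. For compound 4 the reported < 10 nM is a limit of the assay, so the step has a bound and not an exact size: the limit of < 10 nM in this assay, at which 1 of the 4 values shown sits.

The compounds shown leave open how an ethyl group, a methoxy group or an amine on this same carbon would compare. They also leave open whether hydrogen in place of methyl here gives a similar step on a core bearing a different aromatic group.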